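A few compounds are considered here, and "the series" means these few. Any claim that something is new, unique, unknown or untested is made for them only; others in the source may bear on it.

Working notes on the series

The step under study runs from compound 2 `COc1cc(-c2nn(-c3cccc(NC(=O)c4cccc(C(F)(F)F)c4)c3)cc2-c2ccncc2)ccc1Cl` to compound 4 `COc1cc(-c2nn(-c3cccc(NC(=O)Nc4ccc(Cl)c(Cl)c4)c3)cc2-c2ccncc2)ccc1Cl`, and it is read in a functional assay on RXF 393 cells (Homo sapiens) for inhibition, read by sulforhodamine B assay, with a stated time of 48 h; on this read-out lower numbers stand for higher toxicity in this test and higher numbers for lower toxicity in this test.

Compound 2 sits at a limit of this assay, > 50000 nM, and no number is known for it. Its nearest measured relative is compound 1 `COc1cc(-c2nn(-c3cccc(NC(=O)c4ccc(Cl)c(C(F)(F)F)c4)c3)cc2-c2ccncc2)ccc1Cl`. Compound 1 likewise sits at a limit of this assay, > 32500 nM. Within the data shown here, the one step between them, a step that the two limits leave unreadable from compound 1 to compound 2, therefore cannot be sized; both ends of the series rest on the limits the limit of > 32500 nM in this assay, at which 1 of the 3 values shown sits, and (the limit of > 50000 nM in this assay, at which 1 of the 3 values shown sits). Among the measured compounds shown here, compound 3 `O=C(Nc1cccc(-n2cc(-c3ccncc3)c(-c3ccc(Cl)c(O)c3)n2)c1)Nc1cc(C(F)(F)F)cc(C(F)(F)F)c1` is the only member with a number, and in this assay compound 3 gives 10700 nM; it differs from compound 2 in more than one place, so no step to it is read.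

Compound 4 carries the change ((3,4-dichlorophenyl)amino in place of 3-(trifluoromethyl)phenyl on a carbonyl carbon), that is, (3-(trifluoromethyl)phenyl)carbonyl to (3,4-dichlorophenyl)carbamoyl. For the measured compounds named here, no measured step bears directly on this change, so the expectation leans on compound 3, whose value 10700 nM shows that a member of the series can return a number. Compound 4 is therefore estimated at 20000 nM, within 7000 nM to 60000 nM, which means an expected step of an at least 2.5-fold lower number from compound 2 to compound 4 (0.39 log units; beyond the scatter); a limit remains a real possibility.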

Compound 4, concentration lethal to 50% of the cells: > 50000 nM
Compound 4: only a limit was reported (the forecaster's own chance of this, stated with the estimate: 35%); middle value at least 2.5-fold (0.39 log units) away from the limit.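

In this assay compound 4 gives > 50000 nM, a limit and not a number. Compound 1 and compound 2 also stand at limits, so no new step can be read between either of them and compound 4. The compounds shown leave open whether (3,4-dichlorophenyl)amino in place of 3-(trifluoromethyl)phenyl on a carbonyl carbon changes the read-out at all.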